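The source may report more compounds than this note shows. Statements on the series, on what has been measured and on what is new or still open speak of the compounds shown alone.

Measured in an ADME assay on MT4 cells (Homo sapiens) for cytotoxicity, read by XTT assay, with a stated time of 5 days; on this read-out higher numbers stand for lower toxicity in this test and lower numbers for higher toxicity in this test:
Compound 1 `CNC(=O)[C@H](C)NC(=O)[C@@](O)(CCCN(Cc1ccc(Br)cc1)NC(=O)[C@@H](NC(=O)OC)C(C)(C)C)Cc1ccccc1`: > 10000 nM, a limit
Compound 2 `COC(=O)N[C@H](C(=O)NN(CCC[C@@](O)(Cc1ccccc1)C(=O)N[C@H](CO)C(C)(C)C)Cc1ccc(Br)cc1)C(C)(C)C`: > 10000 nM, a limit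
Compound 3 `CNC(=O)[C@@H](NC(=O)[C@@](O)(CCCN(Cc1ccc(-c2ccccc2)cc1)NC(=O)[C@@H](NC(=O)OC)C(C)(C)C)Cc1ccccc1)C(C)(C)C`: > 50000 nM, a limit

Compound 3 has no exact number, only its limit of > 50000 nM. Compound 4 `CNC(=O)[C@@H](NC(=O)[C@@](O)(CCCN(Cc1ccc(C#Cc2ccccn2)cc1)NC(=O)[C@@H](NC(=O)OC)C(C)(C)C)Cc1ccccc1)C(C)(C)C` replaces phenyl with 2-(pyridin-2-yl)ethynyl on an aromatic carbon: 2-(pyridin-2-yl)ethynyl in place of phenyl on an aromatic carbon. Among the compounds with values here, the only measured step, a step that the two limits leave unreadable from compound 1 to compound 2, lies elsewhere, on an amide-type nitrogen, and has no readable size. The other evidence consists of limits: the limit of > 10000 nM in this assay, at which 2 of the 3 values shown sit, and (the limit of > 50000 nM in this assay, at which 1 of the 3 values shown sits). Within the data shown here, no measured step therefore bears on this change, and no direction can be predicted in this assay. The expected change is a number no higher from compound 3 to compound 4 (the limit leaves the size open), with nothing beyond the scatter anticipated. For compound 4 the estimated value is 50000 nM, with an expected range from 15000 nM to 100000 nM.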

Compound 4, half-maximal cytotoxic concentration: > 50000 nM
Compound 4 was reported as a limit; the forecaster's own chance of this, stated with the estimate: 70%; the middle value lies on the limit itself.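

Compound 3 and compound 4 are both reported only as limits in this assay, so the change from phenyl to 2-(pyridin-2-yl)ethynyl cannot be read. The compounds shown leave open whether this change alters cytotoxicity at all.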